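A few compounds are considered here, and "the series" means these few. Any claim that something is new, unique, unknown or untested is made for them only; others in the source may bear on it.

In a functional assay on the whole organism for inhibition, with Lemna aequinoctialis as the target, with a stated time of 7 days, tested at 5 ug/mL (on this read-out lower numbers stand for less inhibition of growth and higher numbers for more inhibition of growth at the one concentration tested), compound 1 `O=C1Nc2ccc(F)cc2/C1=N/NC(=S)Nc1ccc(C(F)(F)F)cc1` gives 10%, compound 2 `O=C1Nc2ccc(F)cc2/C1=N/NC(=S)Nc1ccc(OC(F)(F)F)cc1` gives 10% and compound 3 `O=C1Nc2ccc(F)cc2/C1=N/NC(=S)Nc1cccc(F)c1` gives 15%, so compound 3 lies within the usual scatter of both. Compound 4 `O=C1Nc2ccc(F)cc2/C1=N/NC(=S)Nc1ccc(F)cc1` differs from compound 3 in one place: 4-fluorophenyl in place of 3-fluorophenyl on an amide-type nitrogen. This puts 4-fluorophenyl in place of 3-fluorophenyl on an amide-type nitrogen. Among the compounds with values here, no measured step makes this same change, so the evidence is indirect. Within the data shown here, the one measured step, with trifluoromethoxy in place of trifluoromethyl on an aromatic carbon, shows no change at the digits printed from compound 1 to compound 2 (within the scatter). A step beyond the scatter is therefore not expected in this assay, and no direction is favoured. The expected step is a number 3 percentage points lower from compound 3 to compound 4 (within the scatter). Compound 4 is estimated at 12%, with an expected range from 5% to 25%.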

Compound 4, percent growth inhibition at one concentration: 10%
For compound 4 the middle estimate is 2 percentage points above the measured one, and the stated range covers the measured number.
By their numbers in this assay, from the lowest: compounds 1, 2, 4 and 3 (each within the scatter of the next).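

In this assay, moving the fluorine from 3-fluorophenyl to 4-fluorophenyl on the amide-type nitrogen gives a number 5 percentage points lower from compound 3 to compound 4 (within the scatter) and so does not separate the two compounds. Fluoro in place of trifluoromethoxy gives no change at the digits printed from compound 2 to compound 4 (within the scatter) and fluoro in place of trifluoromethyl gives no change at the digits printed from compound 1 to compound 4 (within the scatter), so these three groups on the aromatic ring cannot be told apart in this test. Nothing available here offers an explanation for these results.

On these data alone, whether an amine, a carboxylic acid or a longer chain on this aromatic ring would shift growth inhibition beyond the scatter remains open. So does the effect of any change to the shared core.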